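A few compounds are considered here, and "the series" means these few. Any claim that something is new, unique, unknown or untested is made for them only; others in the source may bear on it.

Going by the values given here, in a functional assay on HCT-116 cells (Homo sapiens) for inhibition, read by CCK-8 assay, with a stated time of 48 h (a higher number here means a weaker inhibitor, a lower number a stronger inhibitor), three compounds have numbers so far. Compound 1 `COc1cc(-c2ccnc3cc(-c4ccc(F)cc4)nn23)cc(OC)c1OC` gives 5030 nM, compound 3 `Cn1ccc2cc(-c3cc4nccc(-c5ccc(F)cc5)n4n3)ccc21` gives 2160 nM, and compound 2 `COc1cc(-c2ccnc3cc(-c4ccc(C)cc4)nn23)cc(OC)c1OC` gives 48 nM. Compound 2 therefore holds the lowest number of the three, and its gaps to the other two lie well beyond the scatter, which makes it the strongest inhibitor measured so far.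

Compound 4 `COc1cc(-c2ccnc3cc(-c4ccc(C(F)(F)F)cc4)nn23)cc(OC)c1OC` is compound 2 with one change: trifluoromethyl in place of methyl on an aromatic carbon, turning 4-methylphenyl into 4-(trifluoromethyl)phenyl (trifluoromethyl in place of methyl on an aromatic carbon).

Among the compounds with values here, only one measured step bears on this change, and it touches the same group on the same ring. That step is a 100-fold lower number from compound 1 to compound 2 (2.02 log units; beyond the scatter), a large one, where methyl replaced fluoro. It shows how sharply this assay can respond to a small substituent at this spot. It is still a different swap, so it serves only as a rough guide to size. Compound 1 shows that a fluorine-bearing group here can go with a much higher number, so the direction expected is upward, with a wide margin of doubt.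

The estimate is a 13-fold higher number from compound 2 to compound 4 (1.10 log units; beyond the scatter), an expected loss of strength smaller than the one seen in the measured step. For compound 4 the expected value is 600 nM, with an estimated range from 100 nM to 4000 nM.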

Compound 4, half-maximal inhibitory concentration: 1860 nM
Estimate against measurement, compound 4: 3.1-fold (0.49 log units) below; the range from low to high includes it.
By their numbers in this assay, from the lowest: compound 2; then compounds 4 and 3 (each within the scatter of the next); then compound 1.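

In this assay, the swap of methyl for trifluoromethyl on the aromatic carbon para to a large group gives a 39-fold higher number from compound 2 to compound 4 (1.59 log units; beyond the scatter) and so shows that the low number of compound 2 does not survive this change, even though the two groups differ by only a few heavy atoms. Setting trifluoromethyl against fluoro gives a 2.7-fold lower number from compound 1 to compound 4 (0.43 log units; beyond the scatter), a modest step next to the large one from methyl, and the earlier step of a 100-fold lower number from compound 1 to compound 2 (2.02 log units; beyond the scatter) fits the same picture: among these three compounds, only the methyl compound has a low number, while both fluorine-bearing groups leave the number far higher. Nothing shown here explains why methyl stands apart from the two fluorine-bearing groups.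

Still open, from the compounds shown here alone, is whether the low number belongs to methyl alone or extends to other small groups without fluorine, such as ethyl, methoxy or an amine, and whether a longer chain such as propyl would keep it. Going by these compounds, it is also open whether methyl would have a similar effect on a different core, since these steps all share the core of compound 2.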